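A few compounds are considered here, and "the series" means these few. Any claim that something is new, unique, unknown or untested is made for them only; others in the source may bear on it.

Measured so far in a functional assay on MCF7 cells (Homo sapiens) for inhibition, read by MTT assay, with a stated time of 72 h, tested at 30 uM; a higher number here means more inhibition of growth at the concentration tested, a lower number less inhibition of growth:
compound 1 `C=CCc1ccc(OCc2cn(-c3ccccc3CO)nn2)c(O)c1` gives 34.5%
compound 2 `C=CCc1ccc(OCc2cn(-c3cc(OC)c(OC)c(OC)c3)nn2)c(O)c1` gives 37.3%
compound 3 `C=CCc1cc(O)c(O)c(CN2CCC(CCO)CC2)c1` gives 21.4%

Compound 1 stands second highest of the three numbers. Compound 2 lies nearest, with a number higher by an amount within the scatter, so no order between compound 1 and compound 2 can be read. Compound 3 lies furthest, with a number lower by an amount beyond the scatter. Among the measured compounds shown here, no pair of measured compounds that differ in one place is available, so no measured step can be drawn on.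

Compound 4 `C=CCc1ccc(OCc2cn(-c3cccc(C#N)c3)nn2)c(O)c1` has not yet been measured in this assay. It differs from compound 1 in one place: 3-cyanophenyl in place of 2-(hydroxymethyl)phenyl on an aromatic nitrogen. The group that leaves carries a hydrogen-bond donor; the group that enters carries none. Of compounds 1 and 2, which both carry a phenyl group on the aromatic nitrogen, the values lie within the scatter of each other, which gives no sign that the substituent on that phenyl moves the number far.

The step from compound 1 to compound 4 is therefore expected to be small, in either direction, and within the scatter: a number 0.5 percentage points higher from compound 1 to compound 4 (within the scatter). For compound 4 an estimate of 35% is made, with a range from 20% to 50%.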

Compound 4, percent growth inhibition at one concentration: 31.9%
For compound 4 the middle estimate is 3.1 percentage points above the measured one; the measured number falls inside the stated range.
By their numbers in this assay, from the lowest: compound 3; then compounds 4, 1 and 2 (each within the scatter of the next).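

In this assay, among the compounds shown here, the exchange of 2-(hydroxymethyl)phenyl for 3-cyanophenyl on an aromatic nitrogen gives a number 2.6 percentage points lower from compound 1 to compound 4 (within the scatter) and provides the first measured step at this position. For the compounds shown here, the hydrogen-bond donor of the group that leaves is absent from the group that enters, and the nitrile brings a triple bond, yet this pair shows no step that can be read beyond the scatter, so for these two groups the donor is not tied to a readable change in growth inhibition at the concentration tested. No measurement at hand bears on why the step has this size.

Going by these compounds alone, the single step rests on one pair and changes both the substituent and its printed name position on the phenyl, so it cannot separate the loss of the hydroxymethyl group from the arrival of the nitrile. Open as well is whether a phenyl carrying an amine or a carboxylic acid, or a longer alkyl chain in place of the phenyl on that nitrogen, would move the number beyond the scatter.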